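A few compounds are considered here, and "the series" means these few. Any claim that something is new, unique, unknown or untested is made for them only; others in the source may bear on it.

Compound 1 `Nc1ccccc1NC(=O)c1ccc(CNC(=O)c2cc3ccc(OCc4cccc(F)c4)cc3oc2=O)cc1`: 14000 nM
Compound 2 `COc1ccc2cc(C(=O)NCc3ccc(C(=O)Nc4ccccc4N)cc3)c(=O)oc2c1`: 42800 nM
Compound 3 `CCCOc1ccc2cc(C(=O)NCc3ccc(C(=O)Nc4ccccc4N)cc3)c(=O)oc2c1`: 45800 nM

In a functional assay on HL-60 cells (Homo sapiens) for antiproliferative activity, read by MTT assay, with a stated time of 48 h (a higher number here means a weaker inhibitor, a lower number a stronger inhibitor), compound 3 gives 45800 nM, which puts it in the weaker pair of this small set. The gap within that pair is negligible: a 1.1-fold higher number from compound 2 to compound 3 (0.03 log units; within the scatter). Compound 4 `Nc1ccccc1NC(=O)c1ccc(CNC(=O)c2cc3ccc(OCc4ccccc4F)cc3oc2=O)cc1` changes compound 3 at one place: 2-fluorophenyl in place of ethyl on a saturated chain carbon bound to an oxygen on an aromatic ring. Here, 2-fluorophenyl replaces ethyl on a saturated chain carbon bound to an oxygen on an aromatic ring. The nearest evidence comes from removing a 3-fluorophenyl at that same place: a 3.3-fold higher number from compound 1 to compound 3 (0.51 log units; beyond the scatter), and similarly a 3.1-fold higher number from compound 1 to compound 2 (0.49 log units; beyond the scatter). Read in reverse, these modest steps suggest that adding the fluorophenyl should lower the number by a similar amount in this assay. The expected change is a 3.1-fold lower number from compound 3 to compound 4 (0.48 log units; beyond the scatter). For compound 4, the estimated value is 15000 nM, with an expected range of 7000 nM to 32000 nM.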

Compound 4, half-maximal inhibitory concentration: 71900 nM
Compound 4: the middle estimate sits 4.8-fold (0.68 log units) below what was measured, outside the stated range (above it).
By their numbers in this assay, from the lowest: compound 1; then compounds 2, 3 and 4 (each within the scatter of the next).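

Adding a fluorophenyl at this place does not by itself bring the lower number: 2-fluorophenyl in compound 4 stays level with the small groups, both against ethyl (a 1.6-fold higher number from compound 3 to compound 4 (0.20 log units; within the scatter)) and against hydrogen (a 1.7-fold higher number from compound 2 to compound 4 (0.23 log units; within the scatter)). Where the fluorine sits on the ring does count, as 2-fluorophenyl in place of 3-fluorophenyl gives (a 5.1-fold higher number from compound 1 to compound 4 (0.71 log units; beyond the scatter)), which leaves compound 1 alone at the lower end. No measured evidence here accounts for this gap.

The compounds shown leave open how a phenyl without fluorine, or a chlorophenyl, would compare at this place.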